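This account rests on a few compounds, and the source may have more. Where it says the series, first, only, none or still open, it means among the compounds named here.

Measured compounds in a functional assay on MKN-45 cells (Homo sapiens) for cytotoxicity, read by MTT assay, with a stated time of 72 h; a lower number here means a stronger inhibitor, a higher number a weaker inhibitor:
compound 1 `COc1cc2c(Oc3ccc(NC(=O)c4nn(-c5cccc(F)c5)c(=O)c5ccccc45)cc3F)ccnc2cc1OCCCN1CCCC1` gives 160 nM
compound 2 `COc1cc2c(Oc3ccc(NC(=O)c4nn(-c5ccc(Br)cc5)c(=O)c5ccccc45)cc3F)ccnc2cc1OCCCN1CCCC1` gives 230 nM

On the two numbers shown, compound 2 stands with the higher one, yet the step of a 1.4-fold higher number from compound 1 to compound 2 (0.16 log units; within the scatter) is within the scatter, so the two compounds are not separated. Compound 3 `COc1cc2c(Oc3ccc(NC(=O)c4nn(-c5ccc(Br)cc5)c(=O)c5ccccc45)cc3F)ccnc2cc1OCCCN1CCN(C)CC1` is not yet measured; it differs from compound 2 by 4-methylpiperazin-1-yl in place of pyrrolidin-1-yl on a saturated chain carbon, three bonds along the chain from an oxygen on an aromatic ring. Among the compounds with values here, the one measured step concerns the group on the aromatic nitrogen, not this chain end, so no measured step bears on the change. Nothing beyond the scatter is therefore expected in this assay, and the step of a 1.1-fold higher number from compound 2 to compound 3 (0.04 log units; within the scatter) is an estimate at that level. Compound 3 is expected to give 250 nM, ranging from 100 nM to 650 nM.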

Compound 3, half-maximal inhibitory concentration: 350 nM
For compound 3 the middle estimate is 1.4-fold (0.15 log units) below the measured one; measured number inside the range.
By their numbers in this assay, from the lowest: compounds 1, 2 and 3 (each within the scatter of the next, the first and the last beyond it).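

In this assay, within the data shown here, the step of a 1.5-fold higher number from compound 2 to compound 3 (0.18 log units; within the scatter) gives the first reading at the chain end, with the 4-bromophenyl group held fixed. Replacing pyrrolidin-1-yl with 4-methylpiperazin-1-yl therefore does not separate these two compounds, though a single step cannot define this position more broadly. Nothing available accounts for the result.

From the compounds shown here alone, it remains open whether morpholin-4-yl, a dimethylamino group or a longer chain would read differently here. Whether the same exchange would hold alongside the 3-fluorophenyl group of compound 1 is also unresolved.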